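A few compounds are considered here, and "the series" means these few. Any claim that something is new, unique, unknown or untested is made for them only; others in the source may bear on it.

Measured compounds:
Compound 1 `c1ccc2c(c1)CCC2c1ncc[nH]1`, in a functional assay on CHO cells for agonist activity at Alpha-1A adrenergic receptor (Homo sapiens), read by FLIPR and calcium flux (on this read-out higher numbers stand for an effect only at larger amounts of compound and lower numbers for an effect already at smaller amounts), compound 1 gives 473 nM.
Compound 2 `c1cncc(-c2cccc3c2CCC3c2ncc[nH]2)c1`, in this assay compound 2 gives 2060 nM.

Compound 2 stands at the highest of the two numbers shown; the only neighbour, compound 1, lies lower by a 4.4-fold higher number from compound 1 to compound 2 (0.64 log units; beyond the scatter). The new compound, compound 3 `CNC(=O)c1cccc2c1CCC2c1ncc[nH]1`, differs from compound 2 in one place: methylcarbamoyl in place of pyridin-3-yl on an aromatic carbon.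

Going by the values given here, only one measured step bears on this change, the one from compound 1 to compound 2, a 4.4-fold higher number from compound 1 to compound 2 (0.64 log units; beyond the scatter), which shows that placing pyridin-3-yl on this aromatic carbon raised the number modestly but beyond the scatter. Among the compounds with values here, no measured pair shows methylcarbamoyl at this place, so its effect is not directly known. Since methylcarbamoyl is a smaller group than pyridin-3-yl, the expectation is that compound 3 lands between compound 1 and compound 2, a step of a 1.7-fold lower number from compound 2 to compound 3 (0.23 log units; within the scatter) from compound 2, downward but likely still within or near the scatter. For compound 3 the estimate in this assay is therefore 1200 nM, with a range from 400 nM to 3500 nM.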

Compound 3, half-maximal effective concentration: 2200 nM
Compound 3: the middle estimate sits 1.8-fold (0.26 log units) below what was measured, and the stated range covers the measured number.
By their numbers in this assay, from the lowest: compound 1; then compounds 2 and 3 (each within the scatter of the next).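

In this assay, exchanging pyridin-3-yl for methylcarbamoyl on this aromatic carbon gives no readable change (a 1.1-fold higher number from compound 2 to compound 3 (0.03 log units; within the scatter)), so the smaller group with no ring does not bring the number back towards that of compound 1. Compared directly with hydrogen at the same place, methylcarbamoyl gives a step (a 4.7-fold higher number from compound 1 to compound 3 (0.67 log units; beyond the scatter)) of much the same size as the one seen earlier with pyridin-3-yl (a 4.4-fold higher number from compound 1 to compound 2 (0.64 log units; beyond the scatter)), so among these three compounds, both groups on this carbon go with a higher number than hydrogen, and neither a ring nor the amide hydrogen separates the two substituted compounds. Nothing measured here explains why the two groups stand so close on this read-out.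

Going by these compounds, it stays open whether a group much smaller than these, such as fluorine or methyl, would stay level with compound 1 on this aromatic carbon, or whether a carboxylic acid, an amine or a dimethylcarbamoyl group, which lacks the amide hydrogen, would move the number away from compound 2 and compound 3. The compounds shown also leave open how pyridin-3-yl or methylcarbamoyl would behave on any other aromatic carbon of the core.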